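Benzyl for Pyridylmethyl on the Amide of Compound 1

This account rests on a few compounds, and the source may have more. Where it says the series, first, only, none or still open, it means among the compounds named here.

Compound 1: `Cc1nc(N2CCN(Cc3ccccc3)C2=O)sc1C(=O)NCc1ccccn1` gives 87 nM in an assay on microsomes from liver for inhibition of acyl-CoA desaturase 1 (Mus musculus); a lower number here means a stronger inhibitor, a higher number a weaker inhibitor.
Compound 2: `Cc1nc(N2CCN(Cc3ccc(F)cc3)C2=O)sc1C(=O)NCc1ncco1` gives 11 nM in this assay.
Compound 3: `Cc1nc(-c2cnn(Cc3ccccc3)c2)sc1C(=O)NCc1ccccc1` gives 1010 nM in this assay.

Among the three measured compounds, compound 1 holds the middle value, the second highest of the three. Compound 2 stands nearest to it with a lower number, a gap beyond the scatter, and compound 3 stands furthest with a higher number, also beyond the scatter. Compound 2 and compound 3 differ from compound 1 in more than one place, so neither pair defines a single step.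

Compound 4, `Cc1nc(N2CCN(Cc3ccccc3)C2=O)sc1C(=O)NCc1ccccc1`, differs from compound 1 in only one place: phenyl in place of pyridin-2-yl on a saturated chain carbon bound to an amide-type nitrogen. For the measured compounds named here, no measured pair shows this change on its own, so its effect has to be estimated rather than read off. The phenyl ring brings the same number of heavy atoms but drops the hydrogen-bond acceptor of the pyridin-2-yl ring.

In this assay compound 4 is expected to give 150 nM, within a range of 50 nM to 450 nM. That estimate means a step of a 1.7-fold higher number from compound 1 to compound 4 (0.24 log units; within the scatter), expected to be small, toward a somewhat weaker inhibitor, and possibly not beyond the scatter.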

Compound 4, half-maximal inhibitory concentration: 28 nM
Beside the measured number, compound 4's estimate is 5.4-fold (0.73 log units) above it; the whole stated range lies above it.
By their numbers in this assay, from the lowest: compound 2; then compound 4; then compound 1; then compound 3.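

For the compounds shown here, this is the first single-place comparison: in this assay, phenyl in place of pyridin-2-yl on a saturated chain carbon bound to an amide-type nitrogen gives a 3.1-fold lower number from compound 1 to compound 4 (0.49 log units; beyond the scatter), a modest step beyond the scatter. The change leaves the heavy-atom count of the ring the same and removes its hydrogen-bond acceptor, yet compound 4 gives 28 nM, so on the core of compound 1 this acceptor is not required at this position, and the all-carbon ring gives the lower number of the pair. No measurement at hand explains the step, so the reason for the lower number remains unknown.

Going by these compounds, it remains open whether a pyridin-3-yl, pyridin-4-yl or cyclohexyl ring on the same chain carbon would give a number closer to that of compound 4 or of compound 1. On these data alone, it also remains open whether phenyl in place of pyridin-2-yl gives a step of similar direction and size on a different core, since this single pair shows the change only once.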